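This account rests on a few compounds, and the source may have more. Where it says the series, first, only, none or still open, it means among the compounds named here.

Measured compounds in an assay on Sf9 cells for inhibition of protein deacetylase HDAC6 (Homo sapiens), read by fluorescence, with a stated time of 40 min, tested at 100 nM; on this read-out higher numbers stand for more inhibition at the one concentration tested (going by the name of the read-out) and lower numbers for less inhibition:
compound 1 `Cc1ccccc1-n1nc(-c2ccccc2)nc1CNc1ccc(C(=O)NO)cc1`, 57.1%;
compound 2 `O=C(O)c1ccc(NCc2nc(-c3ccccc3)nn2-c2ccccc2)cc1`, -0.4%;
compound 3 `O=C(NO)c1ccc(NCc2nc(-c3ccco3)nn2-c2ccccc2)cc1`, 59.9%.

Compound 3 gives the highest of the three numbers in this assay, but compound 1 lies within the scatter of it, so the two cannot be ordered; compound 2 lies far below it, beyond the scatter. Compound 4 `CC(C)c1ccc(-c2nc(CNc3ccc(C(=O)NO)cc3)n(-c3ccccc3)n2)cc1` has not yet been measured. It differs from compound 3 in one place: 4-isopropylphenyl in place of furan-2-yl on an aromatic carbon. Within the data shown here, no step between measured compounds covers a change of this kind, so its direction is open. Because compound 1, which also carries a phenyl group rather than a furan-2-yl, gives 57.1%, no step beyond the scatter is expected in this assay. Compound 4 is therefore estimated at 55%, between 35% and 75%. The step of a number 4.9 percentage points lower from compound 3 to compound 4 (within the scatter) is expected to be small.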

Compound 4, a percentage reported as inhibition, at one concentration (the size of the read-out at that concentration, not a potency): 27.6%
Compound 4: the middle estimate sits 27.4 percentage points above what was measured; the measured number lies below the stated range.
By their numbers in this assay, from the lowest: compound 2; then compound 4; then compounds 1 and 3 (each within the scatter of the next).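

In this assay, this aromatic carbon between two ring nitrogen atoms proves sensitive to its group: 4-isopropylphenyl in place of furan-2-yl gives a number 32.3 percentage points lower from compound 3 to compound 4 (beyond the scatter). The change replaces a five-membered aromatic ring with 1 hetero atom by a six-membered aromatic ring of carbon only and also brings in the isopropyl group, and this single step cannot separate those differences. Nothing measured here accounts for the step.

Going by these compounds, it remains open what a plain phenyl on this carbon would give with the rest of compound 3 unchanged. The same holds for thiophen-2-yl or 4-methoxyphenyl there.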